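The source may hold more compounds than are shown below. What is called first, only, known or untested is meant among the compounds shown, and "the series" means these compounds.

Measured so far:
- Compound 1 `O=c1[nH]c(=O)n([C@H]2C[C@H](O)[C@@H](CO)O2)cc1C#CCCCCCCCCCF`: 200000 nM
- Compound 2 `O=c1[nH]c(=O)n([C@H]2C[C@H](O)[C@@H](CO)O2)cc1C#CCCCCCCCCCCl`: 200000 nM

In a functional assay for cytotoxicity, read by microscopy (a lower number here means that less compound is tolerated, a higher number that more compound is tolerated), compound 1 gives 200000 nM, and compound 2 gives 200000 nM. Within the data shown here, the single measured step is no change at the digits printed from compound 1 to compound 2 (within the scatter), so compound 2 stands level with compound 1, the only neighbour it has.

Compound 3 `O=c1[nH]c(=O)n([C@H]2C[C@H](O)[C@@H](CO)O2)cc1C#CCCCCCCCCCBr` differs from compound 2 by bromo in place of chloro on a saturated chain carbon, nine bonds along the chain from a triple-bonded carbon. Among the measured compounds shown here, the one measured step that bears on this is no change at the digits printed from compound 1 to compound 2 (within the scatter), which is the same kind of change, one halogen exchanged for another at the same place on the chain, and it produced nothing beyond the scatter. On that basis the expected step in this assay is no change at the digits printed from compound 2 to compound 3 (within the scatter), that is, no shift beyond the scatter in either direction. Compound 3 is therefore estimated at 200000 nM, within a range of 100000 nM to 400000 nM.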

Compound 3, minimum cytotoxic concentration: 50000 nM
Beside the measured number, compound 3's estimate is 4.0-fold (0.60 log units) above it, and the stated range ends above it.
By their numbers in this assay, from the lowest: compound 3; then compounds 1 and 2 (each within the scatter of the next).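

In this assay bromo in place of chloro gives a 4.0-fold lower number from compound 2 to compound 3 (0.60 log units; beyond the scatter) and bromo in place of fluoro gives a 4.0-fold lower number from compound 1 to compound 3 (0.60 log units; beyond the scatter) at this same place on the chain. The exchange of fluoro for chloro had moved nothing beyond the scatter, so the earlier pair alone gave no sign that this position could respond to a change of halogen, yet a single bromine atom here does shift the number, towards less compound being tolerated. Nothing shown here accounts for the shift, and its cause stays unknown.

From the compounds shown here alone, what remains open is whether iodo at the chain end would lower the number further or leave it where it is. Going by these compounds, it is equally open whether bromo would give the same step on a shorter or longer chain, and how a hydroxyl or an amine at this place would compare.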